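The compounds below may be only part of what the source reports. "The series", "measured", "known", "first", "only" and "open" are said of these compounds alone.

Measured so far in a functional assay on RPMI 8402 cells (Homo sapiens) for cytotoxicity; a higher number here means a weaker inhibitor, a lower number a stronger inhibitor:
compound 1 `Cc1cccc(-c2nc3cc(-c4nc5cc(C(N)=O)ccc5[nH]4)ccc3[nH]2)c1`: 8200 nM
compound 2 `Cc1ccc(-c2nc3cc(-c4nc5cc(C(N)=O)ccc5[nH]4)ccc3[nH]2)cc1`: > 25000 nM

Compound 2 gives only a limit in this assay, (the limit of > 25000 nM in this assay, at which 1 of the 2 values shown sits). The step from compound 2 to compound 3 `NC(=O)c1ccc2[nH]c(-c3ccc4[nH]c(-c5cccc6ccccc56)nc4c3)nc2c1` is naphthalen-1-yl in place of 4-methylphenyl on an aromatic carbon. Among the measured compounds shown here, the one measured step, an at least 3.0-fold higher number from compound 1 to compound 2 (0.48 log units; beyond the scatter), shows that the 4-methylphenyl of compound 2 is the weaker of the two aryl groups. Compound 3 drops that group for naphthalen-1-yl, so the loss seen for compound 2 is expected to be partly undone, giving an at least 2.5-fold lower number from compound 2 to compound 3 (0.39 log units; beyond the scatter). Compound 3 is therefore estimated at 10000 nM, within 2500 nM to 40000 nM.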

Compound 3, half-maximal inhibitory concentration: 3700 nM
For compound 3 the middle estimate is 2.7-fold (0.43 log units) above the measured one, within the range that was stated.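

On the aromatic carbon between two ring nitrogen atoms, naphthalen-1-yl gives the lowest number of the three aryl groups, with an at least 6.7-fold lower number from compound 2 to compound 3 (0.82 log units; beyond the scatter) and a 2.2-fold lower number from compound 1 to compound 3 (0.35 log units; beyond the scatter). This position therefore accepts two six-membered aromatic rings of carbon only, and no methylphenyl is needed for the lower number. Compound 2 is held only by a limit: the limit of > 25000 nM in this assay, at which 1 of the 3 values shown sits.

Every group shown here is carbon only, so what a phenyl ring bearing an amine or a carboxylic acid would give in this assay stays open. So does the result for naphthalen-2-yl at this position.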